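The source may hold more compounds than are shown below. What is called first, only, known or untested is meant among the compounds shown, and "the series" means these compounds.

Measured in a functional assay on B16 cells (Mus musculus) for antiproliferative activity, with a stated time of 72 h; on this read-out lower numbers stand for stronger inhibition and higher numbers for weaker inhibition:
Compound 1 `COc1cc(CNc2ncnc3c2ncn3[C@@H]2O[C@H](CO)[C@@H](O)[C@H]2O)cc(OC)c1`: "not determined" (no result reported)
Compound 2 `OC[C@H]1O[C@@H](n2cnc3c(NCc4c(F)ccc(F)c4F)ncnc32)[C@H](O)[C@@H]1O`: > 166000 nM

Compound 1 has no reported result, which leaves compound 2 as the only reference point. Compound 2 stands at > 166000 nM, which is a limit of the assay and not a number.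

Compound 3 `OC[C@H]1O[C@@H](n2cnc3c(NCc4ccc(F)c(Cl)c4)ncnc32)[C@H](O)[C@@H]1O` keeps the shared core but carries 3-chloro-4-fluorophenyl in place of 2,3,6-trifluorophenyl on a saturated chain carbon bound to a nitrogen on an aromatic ring. Within the data shown here, no measured step is available to size such a change in this assay. The expectation therefore rests on compound 2 alone, with the limit of > 166000 nM in this assay, at which 1 of the 2 values shown sits. A modest move towards stronger inhibition is expected, an estimated at least 1.6-fold lower number from compound 2 to compound 3 (0.22 log units; that floor lies within the scatter). The estimated value for compound 3 is 100000 nM, with an expected range from 25000 nM to 166000 nM.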

Compound 3, half-maximal inhibitory concentration: 167000 nM
Beside the measured number, compound 3's estimate is 1.7-fold (0.22 log units) below it; the measured number lies above the stated range.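

In this assay, no step can be read from compound 2 to compound 3, since compound 2 carries only a limit: the limit of > 166000 nM in this assay, at which 1 of the 3 values shown sits.

The compounds shown leave open how 3-chloro-4-fluorophenyl and 2,3,6-trifluorophenyl compare in this assay, and whether any group at this place gives stronger inhibition.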